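Methylating the Amide Nitrogen: Cytotoxicity Expected Unchanged

The compounds below may be only part of what the source reports. "The series", "measured", "known", "first", "only" and "open" are said of these compounds alone.

Compound 1 `COc1cnc(-n2cc(C)cn2)c2[nH]cc(C(=O)C(=O)N3CCN(C(=O)c4ccccc4)CC3)c12` carries a 4-methyl-1H-pyrazol-1-yl group on an aromatic carbon of the shared core; in a functional assay on MT2 cells (Homo sapiens) for cytotoxicity, read by XTT assay, with a stated time of 3 days (on this read-out lower numbers stand for higher toxicity in this test and higher numbers for lower toxicity in this test), compound 1 gives 243000 nM. Compound 2 `CNC(=O)c1ncn(-c2ncc(OC)c3c(C(=O)C(=O)N4CCN(C(=O)c5ccccc5)CC4)c[nH]c23)n1` has 3-(methylcarbamoyl)-1H-1,2,4-triazol-1-yl in place of that group. In this assay compound 2 reaches only the limit of the test, > 300000 nM, so no exact number is known for it. The step of an at least 1.2-fold higher number from compound 1 to compound 2 (0.09 log units; that floor lies within the scatter) can thus be stated only as a floor, because of the limit of > 300000 nM in this assay, at which 1 of the 2 values shown sits. Compound 3 `COc1cnc(-n2cnc(C(=O)N(C)C)n2)c2[nH]cc(C(=O)C(=O)N3CCN(C(=O)c4ccccc4)CC3)c12` differs from compound 2 by methyl in place of hydrogen on an amide-type nitrogen. Within the data shown here, only that single step bears on this change, and it did not clearly leave the scatter, so the added methyl is expected to shift this assay by a number no higher from compound 2 to compound 3 (the limit leaves the size open), meaning no change beyond the scatter. Compound 3 is therefore estimated at 300000 nM, with a likely range from 150000 nM to 600000 nM, and will most probably again show only a limit.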

Compound 3, half-maximal cytotoxic concentration: > 300000 nM
Compound 3: no number, only a limit; the forecaster's own chance of this, stated with the estimate: 70%; the middle value lies on the limit itself.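

With compound 3, a second compound on this triazole stands at the limit of this assay, so the step from hydrogen to methyl on the amide nitrogen cannot be read, and no size can be given for it because both values are limits: the limit of > 300000 nM in this assay, at which 2 of the 3 values shown sit. Among these compounds, the one step that can be read is an at least 1.2-fold higher number from compound 1 to compound 3 (0.09 log units; that floor lies within the scatter), and it is only a floor. Carrying either methylcarbamoyl or dimethylcarbamoyl, the triazole therefore gives no exact number in this test, and the added methyl brings no compound below the limit.

What the compounds shown leave open is how far each of these two lies beyond the limit. An ethyl group on the amide nitrogen, or a carboxylic acid in place of the whole amide, could show whether this position can bring a value below the limit.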